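A Moved Amino Group in Compound 4

The source may report more compounds than this note shows. Statements on the series, on what has been measured and on what is new or still open speak of the compounds shown alone.

Three related compounds have been measured in a physicochemical assay for solubility, read by LC-MS, in phosphate buffer, with a stated time of 24 h, at pH 6.8; a higher number here means a more soluble compound, a lower number a less soluble compound. Compound 1 `C[C@H](NC(=O)C1CCOCC1)c1ccc(NC(=O)N2CC(c3ccc(N)nc3)C2)cc1` gives 310000 nM. Compound 2 `C[C@H](NC(=O)[C@@H]1CCCN1C)c1ccc(NC(=O)N2CC(c3ccc(N)nc3)C2)cc1` gives 760000 nM, and compound 3 `CCC(=O)N[C@@H](C)c1ccc(NC(=O)N2CC(c3ccc(N)nc3)C2)cc1` gives 760000 nM. Compound 2 therefore stands level with compound 3, the two together holding the highest of the three numbers.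

Compound 4 `C[C@H](NC(=O)[C@@H]1CCCN1C)c1ccc(NC(=O)N2CC(c3cncc(N)c3)C2)cc1` has not yet been measured. It differs from compound 2 in one place: 5-aminopyridin-3-yl in place of 6-aminopyridin-3-yl on a saturated ring carbon. The two have the same atoms, joined differently, with 5-aminopyridin-3-yl in place of 6-aminopyridin-3-yl on a saturated ring carbon of a four-membered non-aromatic ring.

The measured steps all concern a different place, the group on a carbonyl carbon. Putting 1-methylpyrrolidin-2-yl in place of oxan-4-yl gave a 2.5-fold higher number from compound 1 to compound 2 (0.39 log units; beyond the scatter), ethyl in place of oxan-4-yl gave a 2.5-fold higher number from compound 1 to compound 3 (0.39 log units; beyond the scatter), and ethyl in place of 1-methylpyrrolidin-2-yl gave no change at the digits printed from compound 2 to compound 3 (within the scatter). None of these steps alters the aminopyridinyl group, so the data offer no direct guide to this change and no direction for it. They supply only a sense of scale, and a step beyond the scatter is not expected. The estimated step is no change at the digits printed from compound 2 to compound 4 (within the scatter). For compound 4 the expected value in this assay is 760000 nM, with an estimated range from 300000 nM to 1900000 nM.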

Compound 4, solubility: 820000 nM
Estimate against measurement, compound 4: 1.1-fold (0.03 log units) below; measured number inside the range.
By their numbers in this assay, from the lowest: compound 1; then compounds 2, 3 and 4 (each within the scatter of the next).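

Among the compounds shown here, until now every measured step concerned the group on a carbonyl carbon, so compound 4 gives the first reading at a different place, on a saturated ring carbon of a four-membered non-aromatic ring with 1 nitrogen. In this assay, moving the amino group so that 5-aminopyridin-3-yl stands in place of 6-aminopyridin-3-yl gives a 1.1-fold higher number from compound 2 to compound 4 (0.03 log units; within the scatter) and so, with 1-methylpyrrolidin-2-yl held fixed on the carbonyl carbon, this read-out does not tell the two arrangements of the same atoms apart. No measurement shown bears on the reason for this result.

The compounds shown carry this swap only alongside 1-methylpyrrolidin-2-yl, so it remains open whether the two aminopyridinyl groups would also read alike alongside the oxan-4-yl group of compound 1 or the ethyl group of compound 3. Also open, from the compounds shown here alone, is how the number would respond if a different group took this place on the four-membered ring, such as a pyridine ring bearing a methoxy group instead of the amine, or a phenyl ring bearing a carboxylic acid.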